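Pentyloxy replacement on the aromatic carbon: compound 3 to compound 4

The compounds below may be only part of what the source reports. "The series", "measured", "known", "first", "only" and "open" are said of these compounds alone.

Values in a functional assay on the whole organism (strain Sprague-Dawley) for inhibition, with Rattus norvegicus as the target, with a stated time of 10 min (on this read-out lower numbers stand for an effect already at smaller amounts and higher numbers for an effect only at larger amounts of compound), so far
Compound 1 `O=C(O)c1cnc(-c2ccccc2[N+](=O)[O-])[nH]c1=O` gives > 50 mg/kg as a limit.
Compound 2 `O=C(O)c1cnc(-c2ccccc2O)[nH]c1=O` gives > 5 mg/kg as a limit.
Compound 3 `CCCCCOc1ccccc1-c1ncc(C(=O)O)c(=O)[nH]1` gives 3 mg/kg as a number.

For the measured compounds named here, compound 3 holds the only actual number, and the other two values are limits. Pentyloxy in place of nitro gives an at least 16-fold lower number from compound 1 to compound 3 (1.22 log units; beyond the scatter) as a large step. Pentyl in place of hydrogen on the oxygen gives an at least 1.6-fold lower number from compound 2 to compound 3 (0.22 log units; that floor lies within the scatter) so no order can be read between those two compounds. Hydroxy in place of nitro gives a step that the two limits leave unreadable from compound 1 to compound 2 and adds nothing further.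

The next structure is compound 4 `C[S+]([O-])c1ccccc1-c1ncc(C(=O)O)c(=O)[nH]1` and the change is a group of 3 heavy atoms (1 carbon, 1 oxygen, 1 sulfur; no ring) in place of a group of 6 heavy atoms (5 carbon, 1 oxygen; no ring), on an aromatic carbon at the same aromatic carbon. Pentyloxy leaves, and the only large step measured at this carbon is the one that brought it in, so the step from compound 1 bears most directly. Some of an at least 16-fold lower number from compound 1 to compound 3 (1.22 log units; beyond the scatter) is expected to be lost, though the entering group is not nitro, and no step measures it directly. The expected change is a 3.3-fold higher number from compound 3 to compound 4 (0.52 log units; beyond the scatter) in this assay towards a higher number, with a report of only a limit quite possible. For compound 4 the estimate is 10 mg/kg with an expected range from 2 mg/kg to 50 mg/kg in this estimate.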

Compound 4, dose for 50% inhibition: > 5 mg/kg
Compound 4: only a limit was reported; the forecaster's own chance of this, stated with the estimate: 40%; the middle value does not contradict the limit.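

Compound 4 carries only a limit in this assay: the limit of > 5 mg/kg in this assay, at which 2 of the 4 values shown sit. Pentyloxy giving way to the group of 3 heavy atoms (1 carbon, 1 oxygen, 1 sulfur) yields an at least 1.6-fold higher number from compound 3 to compound 4 (0.22 log units; that floor lies within the scatter), so no order can be read between these two compounds, and the steps to compound 4 from compound 1 and compound 2 cannot be read at all. For the compounds shown here, at this aromatic carbon, ortho to a large group, a third group besides pentyloxy now ends in a limit, which leaves compound 3 still the only compound with an actual number.

Going by these compounds, how far the true value of compound 4 lies from its limit stays open, and with it whether this change costs anything measurable. Also open, on these data alone, is what an ethoxy or butoxy group, a longer chain such as decyloxy, or an amine would give at the same carbon, which would separate the part played by the chain from that of the oxygen joined to the ring.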